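The source may report more compounds than this note shows. Statements on the series, on what has been measured and on what is new or still open speak of the compounds shown alone.

Compound 1 `C/C(CC(=O)Nc1nnc(/C=C/c2ccccc2)s1)=N\c1ccccn1` in a physicochemical assay for lipophilicity, measured as octanol-water partition; on this read-out higher numbers stand for higher lipophilicity and lower numbers for lower lipophilicity: 4.23
Compound 2 `CC(=O)Oc1ccccc1-c1nnc(NC(=O)C/C(C)=N/c2ccc([N+](=O)[O-])cn2)s1` in this assay: 3.56

Of these two numbers, compound 1 stands highest; compound 2 lies lower by more than the scatter. Compound 3 `C/C(CC(=O)Nc1nnc(-c2ccc(N)cc2)s1)=N\c1ccccn1` has not yet been measured in this assay. It differs from compound 1 in one place: 4-aminophenyl in place of 2-phenylethenyl on an aromatic carbon. Among the compounds with values here, no measured pair shows this kind of change, so the expectation rests on the structural change alone. The expected step is a number 1.53 log units lower from compound 1 to compound 3 (beyond the scatter), a fall well beyond the scatter. For compound 3 the estimate in this assay is 2.7, ranging from 2.1 to 3.3.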

Compound 3, partition coefficient: 3.3
For compound 3 the middle estimate is 0.60 log units below the measured one; the range from low to high includes it.
By their numbers in this assay, from the lowest: compounds 3 and 2 (each within the scatter of the next); then compound 1.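

On the aromatic carbon of the shared core, the change to 4-aminophenyl from 2-phenylethenyl moves this assay by a number 0.93 log units lower from compound 1 to compound 3 (beyond the scatter), so this position responds to the swap by a modest step. Both groups carry one six-membered aromatic ring of carbon only, while the entering group brings 1 hydrogen-bond donor and 1 hydrogen-bond acceptor. No evidence at hand gives a cause for this step.

The pair leaves open how much of the step belongs to the amine and how much to the lost double bond outside the ring. A plain phenyl or a 4-hydroxyphenyl at this position would help separate the two.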